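Furan-2-yl in place of 3,4-dimethoxyphenyl: working notes

This account rests on a few compounds, and the source may have more. Where it says the series, first, only, none or still open, it means among the compounds named here.

Measured in a functional assay on HCT-116 cells (Homo sapiens) for inhibition, read by sulforhodamine B assay, with a stated time of 48 h, tested at 50 uM (on this read-out lower numbers stand for less inhibition of growth and higher numbers for more inhibition of growth at the one concentration tested), so far:
- compound 1 `COc1ccc(/C=C/C(=O)/C=C/c2ccc(OCc3cn(CCCCCOc4cc(=O)oc5ccccc45)nn3)c(OC)c2)cc1OC` gives 45% here
- compound 2 `COc1cc(/C=C/C(=O)/C=C/c2ccco2)ccc1OCc1cn(CCCOc2cc(=O)oc3ccccc23)nn1` gives 51% here
- compound 3 `COc1ccccc1/C=C/C(=O)/C=C/c1ccc(OCc2cn(CCCCOc3cc(=O)oc4ccccc34)nn2)c(OC)c1` gives 43% here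

Compound 1 lies within the scatter of both compound 2 and compound 3, so the three values do not separate. Compound 4 `COc1cc(/C=C/C(=O)/C=C/c2ccco2)ccc1OCc1cn(CCCCCOc2cc(=O)oc3ccccc23)nn1` is still unmeasured. It has furan-2-yl in place of 3,4-dimethoxyphenyl on a double-bonded chain carbon bound to a double-bonded chain carbon. Among the compounds with values here, no step between measured compounds isolates this change. Compound 2 also carries furan-2-yl and gives 51% in this assay so no shift beyond the scatter is expected. The expected size is a number 3 percentage points higher from compound 1 to compound 4 (within the scatter) and this stays within the scatter. For compound 4 the estimate is 48% with 37% to 59% as the expected range.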

Compound 4, percent growth inhibition at one concentration: 37%
For compound 4 the middle estimate is 11 percentage points above the measured one, and the stated range covers the measured number.
By their numbers in this assay, from the lowest: compounds 4, 3, 1 and 2 (each within the scatter of the next, the first and the last beyond it).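

In this assay the exchange of 3,4-dimethoxyphenyl for furan-2-yl, on a double-bonded chain carbon bound to a double-bonded chain carbon, now reads directly as a number 8 percentage points lower from compound 1 to compound 4 (within the scatter), so at this position the exchange does not separate from the scatter. Compound 2 gives 51% and compound 4 gives 37%, so carrying furan-2-yl does not by itself set the value. Nothing measured here bears on a cause for this step.

Going by these compounds, whether an unsubstituted phenyl or a pyridine ring at this position would move the value beyond the scatter remains open.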